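Thiophen-2-yl to thiophen-3-yl in an amide series

This account rests on a few compounds, and the source may have more. Where it says the series, first, only, none or still open, it means among the compounds named here.

Measured so far in a functional assay on SF-295 cells (Homo sapiens) for inhibition, read by colorimetric assay and sulforhodamine B assay, with a stated time of 48 h (on this read-out higher numbers stand for weaker inhibition of growth and lower numbers for stronger inhibition of growth), are:
compound 1 `CCCCCCCCCCCC[C@@H](O)[C@H]1CC[C@H]([C@H](O)CCCCCCCCCCNC(=O)c2cccs2)O1` with 1410 nM
compound 2 `CCCCCCCCCCCC[C@@H](O)[C@H]1CC[C@H]([C@H](O)CCCCCCCCCCNC(=O)c2ccco2)O1` with 33900 nM
compound 3 `CCCCCCCCCCCC[C@@H](O)[C@H]1CC[C@H]([C@H](O)CCCCCCCCCCNC(=O)c2ccoc2)O1` with 100000 nM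

Compound 1 has the lowest number of the three and so shows the strongest inhibition of growth among them. The measured steps away from it are large and beyond the scatter, with a 24-fold higher number from compound 1 to compound 2 (1.38 log units; beyond the scatter) and a 71-fold higher number from compound 1 to compound 3 (1.85 log units; beyond the scatter) as the furan replacements. Compound 4 `CCCCCCCCCCCC[C@@H](O)[C@H]1CC[C@H]([C@H](O)CCCCCCCCCCNC(=O)c2ccsc2)O1` has not yet been measured. It differs from compound 1 by thiophen-3-yl in place of thiophen-2-yl on a carbonyl carbon as thiophen-3-yl in place of thiophen-2-yl on a carbonyl carbon.

Among the compounds with values here, the closest precedent is the same change of attachment within the furans. There a 2.9-fold higher number from compound 2 to compound 3 (0.47 log units; beyond the scatter) is a modest step beyond the scatter. This single pair points to a modest rise in the number, but it cannot show that a thiophene pair will behave alike. The estimate therefore means an expected 2.8-fold higher number from compound 1 to compound 4 (0.45 log units; beyond the scatter) with a wide margin. In this assay the estimate for compound 4 is 4000 nM with 1200 nM to 15000 nM as the expected range.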

Compound 4, concentration for 50% growth inhibition: 1000 nM
Compound 4: the middle estimate sits 4.0-fold (0.60 log units) above what was measured; measured number outside the range, below it.
By their numbers in this assay, from the lowest: compounds 4 and 1 (each within the scatter of the next); then compound 2; then compound 3.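

In this assay the thiophene amides behave differently from the furan pair: thiophen-3-yl in place of thiophen-2-yl on a carbonyl carbon gives a 1.4-fold lower number from compound 1 to compound 4 (0.15 log units; within the scatter), whereas the matching furan change gave a 2.9-fold higher number from compound 2 to compound 3 (0.47 log units; beyond the scatter). The thiophene ring also keeps its advantage with either furan for comparison, since thiophen-3-yl in place of furan-3-yl gives a 100-fold lower number from compound 3 to compound 4 (2.00 log units; beyond the scatter), and thiophen-3-yl in place of furan-2-yl gives a 34-fold lower number from compound 2 to compound 4 (1.53 log units; beyond the scatter). Nothing measured here accounts for this gap between the thiophene and furan amides.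

On these data alone, what a phenyl or thiazolyl group would give on the same carbonyl carbon remains open. So does the effect of a chlorine or methyl group on the thiophene ring, and of a shorter chain leading to the amide.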